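The source may hold more compounds than are shown below. What is called first, only, known or untested is meant among the compounds shown, and "the series" means these compounds.

Working notes on the series. For the measured compounds named here, in a functional assay on A549 cells (Homo sapiens) for inhibition (on this read-out lower numbers stand for stronger inhibition of growth and higher numbers for weaker inhibition of growth), compound 1, `C=C1CCC[C@H]2[C@](C)(CC[C@]3(C)CC[C@H]([C@@H](C)C(=O)O)OO3)[C@@H](C)CC[C@]12C`, gives 1450 nM, the lowest of the two numbers measured so far. Going by the values given here, compound 2, `C=C1CCCC(C)(C)C1CC[C@@]1(C)CC[C@H]([C@@H](C)C(=O)O)OO1`, gives 3050 nM in this assay, a higher number than compound 1 by a margin that lies beyond the usual scatter; the two compounds differ in more than one place, so no single step is drawn between them.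

Compound 3, `C=C1CCC[C@H]2[C@](C)(CC[C@]3(C)CC[C@@H]([C@@H](C)C(=O)O)OO3)[C@@H](C)CC[C@]12C`, is the next compound to be measured in this assay. It differs from compound 1 as follows: the two compounds have the same atoms and bonds and differ only in configuration as drawn: 1 of 7 stereo elements differ; a stereocentre at a saturated ring carbon is drawn R in compound 1 and S in compound 3

Among the compounds with values here, no measured pair isolates such a configuration change, so there is no direct precedent for its size or direction. A single inversion at a ring stereocentre on an otherwise unchanged skeleton is expected to move the number only modestly, with the direction uncertain; a slight weakening is taken as the more likely outcome, so the expected step is a 1.4-fold higher number from compound 1 to compound 3 (0.14 log units; within the scatter). Compound 3 is estimated at 2000 nM, within a range from 700 nM to 6000 nM.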

Compound 3, concentration for 50% growth inhibition: 940 nM
The estimate for compound 3 lay 2.1-fold (0.33 log units) above the measured number, within the range that was stated.
By their numbers in this assay, from the lowest: compounds 3 and 1 (each within the scatter of the next); then compound 2.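

In this assay, for the compounds shown here, inverting the stereocentre at a saturated ring carbon from R to S gives a 1.5-fold lower number from compound 1 to compound 3 (0.19 log units; within the scatter), the only pair so far that isolates a single change. This step lies within the scatter, so at this position neither configuration can be ranked over the other, and the read-out shows no clear dependence on the configuration drawn here. Any real gap between the two numbers could come only from this one centre: the fact that compounds 1 and 3 differ only in the configuration as drawn

As far as these compounds go, it remains open whether the same inversion would give a comparably small step on the skeleton of compound 2. From the compounds shown here alone, all three compounds carry a carboxylic acid, so it is also open how a methyl ester or a primary amide in its place would read in this assay, in either configuration.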